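Amino to Acetamido on a Naphthalene Sulfonamide

A few compounds are considered here, and "the series" means these few. Any claim that something is new, unique, unknown or untested is made for them only; others in the source may bear on it.

Of the compounds shown here, three sharing a sulfonamide core have been measured in an assay on thoracic aorta for binding affinity to Endothelin-1 receptor (Rattus norvegicus); on this read-out higher numbers stand for weaker inhibition and lower numbers for stronger inhibition. Compound 1 `CC(=O)Nc1ccc2cccc(S(=O)(=O)Nc3onc(C)c3C)c2c1` gives 870 nM. Compound 2 `Cc1onc(NS(=O)(=O)c2cccc3c(N(C)C)cccc23)c1C` gives 15 nM. Compound 3 `Cc1noc(NS(=O)(=O)c2ccc3cc(N)ccc3c2)c1C` gives 600 nM. Among these three numbers compound 3 stands second highest: its nearest neighbour is compound 1, whose value lies within the usual scatter of compound 3, so no order between the two can be claimed, while compound 2 lies far lower, well beyond the scatter.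

Compound 4 `CC(=O)Nc1ccc2cc(S(=O)(=O)Nc3onc(C)c3C)ccc2c1` has not yet been measured. Compared with compound 3 the change is acetyl in place of hydrogen on a nitrogen on an aromatic ring, so amino becomes acetamido. For the measured compounds named here, no measured pair shows this exact change on this core. Compound 1 also carries an acetamido group and sits near compound 3 in this assay, so the step is expected to be small. The step of a 1.3-fold higher number from compound 3 to compound 4 (0.12 log units; within the scatter) is estimated to stay within the scatter. Compound 4 is expected to give about 800 nM, in the range 250 nM to 2500 nM.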

Compound 4, half-maximal inhibitory concentration: 3800 nM
Compound 4: middle estimate off by 4.8-fold (0.68 log units), on the low side, and the stated range ends below it.
By their numbers in this assay, from the lowest: compound 2; then compounds 3 and 1 (each within the scatter of the next); then compound 4.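

In this assay the change from amino to acetamido gives a 6.3-fold higher number from compound 3 to compound 4 (0.80 log units; beyond the scatter) and so weakens inhibition on this core, which means that this nitrogen on an aromatic ring does not take an acetyl without a clear loss. For the compounds shown here, this is the first pair in the set that differs in one place only, so it gives the first direct reading of a single change, though it rests on this one pair. No measurement here accounts for the loss.

The compounds shown leave open whether the loss belongs to the acetyl in particular or would also follow from other groups on this nitrogen, such as a methyl or a methanesulfonyl group. They also leave open whether a longer acyl chain, such as propanoyl, would move the number further in the same direction.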